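Swapping methyl for acetyl at the edge of a limit

This account rests on a few compounds, and the source may have more. Where it says the series, first, only, none or still open, it means among the compounds named here.

In an ADME assay on T29 cells (Homo sapiens) for cytotoxicity, read by sulforhodamine B assay, with a stated time of 3 days (a higher number here means a weaker inhibitor, a lower number a stronger inhibitor), compound 2 (`COCc1cn(Cc2ccc(Cl)cc2)c2ccccc12`) gives > 31600 nM as its reading, which is a limit and not a number. Compound 1 (`CC(O)c1cn(Cc2ccc(Cl)cc2)c2ccccc12`) gives > 31500 nM as its reading, which is also a limit. Neither compound has yet given a number here.

Compound 3 (`CC(=O)OCc1cn(Cc2ccc(Cl)cc2)c2ccccc12`) differs from compound 2 by a single change (acetyl in place of methyl on an oxygen on a saturated carbon) that turns methoxymethyl into acetoxymethyl, with acetyl in place of methyl on an oxygen on a saturated carbon.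

Among the compounds with values here, the only measured step that bears on this is a step that the two limits leave unreadable from compound 1 to compound 2 and it puts methoxymethyl in place of 1-hydroxyethyl on an aromatic carbon. Its size cannot be read, and it offers no measure to carry over. Resting on a step that the two limits leave unreadable from compound 1 to compound 2 as the only guide, the expectation for compound 3 is no step beyond the scatter in this assay and quite possibly another limit.

The expected change is a number no higher from compound 2 to compound 3 (the limit leaves the size open) in size and remains only an estimate. Compound 3 is expected at 31600 nM with an estimated range of 12000 nM to 60000 nM in all.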

Compound 3, half-maximal inhibitory concentration: > 31600 nM
Compound 3: no number, only a limit; the forecaster's own chance of this, stated with the estimate: 70%; the middle value lies on the limit itself.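

In this assay, within the data shown here, compound 3 gives > 31600 nM, which is a limit and not a number, so no step among compound 1, compound 2 and compound 3 can be read. The compounds shown leave open where each would reach its half-maximal reading, and whether swapping 1-hydroxyethyl, methoxymethyl and acetoxymethyl changes that reading at all.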